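A few compounds are considered here, and "the series" means these few. Any claim that something is new, unique, unknown or untested is made for them only; others in the source may bear on it.

Compound 3 `COc1cc(N(Cc2nc3ccccc3[nH]2)S(=O)(=O)c2ccc(C)cc2)cc(OC)c1OC` gives 3340 nM in a functional assay on PC-3 cells (Homo sapiens) for inhibition, read by MTT assay, with a stated time of 48 h; a lower number here means a stronger inhibitor, a higher number a weaker inhibitor. Among the three measured compounds it carries the lowest number. Compound 2 `COc1cc(N(Cc2ccc(Br)cc2)S(=O)(=O)c2ccc(C)cc2)cc(OC)c1OC` gives 4680 nM, and the gap a 1.4-fold lower number from compound 2 to compound 3 (0.15 log units; within the scatter) stays within the scatter, so these two cannot be ordered. Compound 1 `COc1cc(N(Cc2ccc(Cl)cc2)S(=O)(=O)c2ccc(C)cc2)cc(OC)c1OC` gives 14600 nM; here the change a 4.4-fold lower number from compound 1 to compound 3 (0.64 log units; beyond the scatter) lies beyond the scatter, as does a 3.1-fold lower number from compound 1 to compound 2 (0.49 log units; beyond the scatter).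

Compound 4 `COc1cc(N(Cc2nc3ccccc3[nH]2)S(=O)(=O)c2ccc(Br)cc2)cc(OC)c1OC` differs from compound 3 in one place: bromo in place of methyl on an aromatic carbon, on an aromatic carbon of a six-membered aromatic ring of carbon only, so that the (4-methylphenyl)sulfonyl group becomes a (4-bromophenyl)sulfonyl group. Within the data shown here, no measured step touches this ring. Among the measured compounds shown here, the steps that exist exchange the group on the saturated chain carbon bound to the sulfonamide nitrogen, and the one halogen exchange, a 3.1-fold lower number from compound 1 to compound 2 (0.49 log units; beyond the scatter), swaps one halogen for another on that other aromatic ring. All of those steps were modest, and none of them speaks to a methyl giving way to a bromo on the sulfonyl aryl. One therefore expects a step of a 1.3-fold lower number from compound 3 to compound 4 (0.13 log units; within the scatter) in this assay, a change that may well not exceed the scatter. The estimate for compound 4 in this assay is 2500 nM, with a range from 800 nM to 8000 nM.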

Compound 4, half-maximal inhibitory concentration: 6890 nM
Beside the measured number, compound 4's estimate is 2.8-fold (0.44 log units) below it; the range from low to high includes it.
By their numbers in this assay, from the lowest: compounds 3, 2 and 4 (each within the scatter of the next, the first and the last beyond it); then compound 1.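

Among these compounds, until now no step touched this ring, and in this assay the exchange of methyl for bromo, on an aromatic carbon para to a large group, gives a 2.1-fold higher number from compound 3 to compound 4 (0.31 log units; beyond the scatter) with the 1H-benzimidazol-2-yl group held constant, so the position is not indifferent to what it carries, though the step is modest. Bromo entering does not go with a lower number everywhere among these compounds: the exchange of chloro for bromo on the other aromatic ring gave a 3.1-fold lower number from compound 1 to compound 2 (0.49 log units; beyond the scatter) and so ran the opposite way, although a different group left there and the ring was a different one. No measured information at hand accounts for this step.

With only methyl and bromo shown on the sulfonyl aryl ring, the compounds leave open how a methoxy, an amine or a carboxylic acid at this position would read, and whether the higher number belongs to bromo alone or would also come with chloro. They also leave open whether the same exchange gives a step of similar size when a 4-chlorophenyl or 4-bromophenyl group replaces the 1H-benzimidazol-2-yl group on the saturated chain carbon.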